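From 4-Bromophenyl to Cyclopropyl on Compound 1

This account rests on a few compounds, and the source may have more. Where it says the series, first, only, none or still open, it means among the compounds named here.

Compound 1 `COc1nc2ccc(Br)cc2cc1C(c1ccccc1)n1cc(-c2ccc(Br)cc2)nn1` gives 10.4% in an ADME assay on PANC-1 cells (Homo sapiens) for cytotoxicity, read by sulforhodamine B assay, with a stated time of 48 h, tested at 10 uM; a higher number here means more inhibition at the concentration tested (going by the name of the read-out), a lower number less inhibition.
Compound 2 `CCOC(=O)c1cn(C(c2ccccc2)c2cc3cc(Br)ccc3nc2OC)nn1` gives 15.4% in this assay.
Compound 3 `CCCc1cn(C(c2ccccc2)c2cc3cc(Br)ccc3nc2OC)nn1` gives 11.3% in this assay.

Compound 1 shows the lowest of the three numbers, yet both differences to it lie within the scatter: a number 0.9 percentage points higher from compound 1 to compound 3 (within the scatter) and a number 5 percentage points higher from compound 1 to compound 2 (within the scatter). The comparison between the two other compounds, a number 4.1 percentage points lower from compound 2 to compound 3 (within the scatter), is also within the scatter. Compound 4 `COc1nc2ccc(Br)cc2cc1C(c1ccccc1)n1cc(C2CC2)nn1` differs from compound 1 in one place: cyclopropyl in place of 4-bromophenyl on an aromatic carbon. The measured step that bears most closely, a number 0.9 percentage points higher from compound 1 to compound 3 (within the scatter), put propyl in place of 4-bromophenyl on the same aromatic carbon; the other, a number 5 percentage points higher from compound 1 to compound 2 (within the scatter), put ethoxycarbonyl there. Neither moved the read-out beyond the scatter, so for this assay no step beyond the scatter is expected from the cyclopropyl change either. Compound 4 is therefore expected to give 11.5%, with a range from 3% to 22%. The estimated step of a number 1.1 percentage points higher from compound 1 to compound 4 (within the scatter) is expected to stay within the scatter.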

Compound 4, a percentage reported as inhibition, at one concentration (the size of the read-out at that concentration, not a potency): 21.8%
The estimate for compound 4 lay 10.3 percentage points below the measured number; the range from low to high includes it.
By their numbers in this assay, from the lowest: compounds 1, 3, 2 and 4 (each within the scatter of the next, the first and the last beyond it).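

In this assay, among the compounds shown here, cyclopropyl is the first group on this aromatic carbon to move the read-out beyond the scatter, with a number 11.4 percentage points higher from compound 1 to compound 4 (beyond the scatter) and a number 10.5 percentage points higher from compound 3 to compound 4 (beyond the scatter), so the position is not indifferent to what it carries, and a three-membered ring and a propyl chain are told apart here. Against ethoxycarbonyl the same replacement stays inside the scatter, with a number 6.4 percentage points higher from compound 2 to compound 4 (within the scatter), so the gain holds against only two of the three earlier groups. Nothing on hand explains these steps.

On these data alone, it remains open whether the step belongs to cyclopropyl alone or extends to other small rings, such as cyclobutyl, or to a short chain ending in an amine. Readings at a single concentration also leave the potency of compound 4 open.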